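This account rests on a few compounds, and the source may have more. Where it says the series, first, only, none or still open, it means among the compounds named here.

Working notes on the series, read in an ADME assay on L02 cells (Homo sapiens) for cytotoxicity, read by MTT assay, with a stated time of 24 h; on this read-out lower numbers stand for stronger inhibition and higher numbers for weaker inhibition. Compound 1 `CN1C/C(=C\c2ccncc2)C(=O)/C(=C/c2ccccc2C(F)(F)F)C1` gives 15800 nM, compound 2 `O=C1/C(=C/c2ccncc2)CN(S(=O)(=O)c2ccccc2)C/C1=C\c1ccccc1C(F)(F)F` gives 12300 nM and compound 3 `O=C1/C(=C/c2ccncc2)CN(S(=O)(=O)c2ccc([N+](=O)[O-])cc2)C/C1=C\c1ccccc1C(F)(F)F` gives 18600 nM. Compound 3 therefore stands within the scatter of both other compounds, and the three values cannot be ranked.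

The next compound is compound 4 `O=C1/C(=C/c2ccncc2)CN(S(=O)(=O)c2ccc(Cl)cc2)C/C1=C\c1ccccc1C(F)(F)F`, and its change from compound 3 is chloro in place of nitro on an aromatic carbon. This is chloro in place of nitro on an aromatic carbon, para to a large group.

The closest measured evidence is the nitro in place of hydrogen change, a 1.5-fold higher number from compound 2 to compound 3 (0.18 log units; within the scatter). The two changes on the ring amine nitrogen, a 1.3-fold lower number from compound 1 to compound 2 (0.11 log units; within the scatter) and a 1.2-fold higher number from compound 1 to compound 3 (0.07 log units; within the scatter), bear on it less directly. Going by the values given here, all three steps are small, but no measured compound carries chloro, so this is an extrapolation.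

No step beyond the scatter is expected in this assay, and no direction is firmly indicated. The estimated change is a 1.2-fold lower number from compound 3 to compound 4 (0.09 log units; within the scatter). Compound 4 is expected at about 15000 nM, with an estimated range of 8000 nM to 28000 nM.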

Compound 4, half-maximal inhibitory concentration: 14900 nM
The estimate for compound 4 lay 1.0-fold (0.00 log units) above the measured number; the range from low to high includes it.
By their numbers in this assay, from the lowest: compounds 2, 4, 1 and 3 (each within the scatter of the next).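

In this assay, chloro now joins hydrogen and nitro on this aromatic carbon, para to a large group, and neither step involving chloro leaves the scatter (a 1.2-fold lower number from compound 3 to compound 4 (0.10 log units; within the scatter); a 1.2-fold higher number from compound 2 to compound 4 (0.08 log units; within the scatter)). On the ring amine nitrogen, (4-chlorophenyl)sulfonyl in place of methyl also stays within the scatter (a 1.1-fold lower number from compound 1 to compound 4 (0.03 log units; within the scatter)), so all three sulfonyl compounds now sit within the scatter of the methyl compound 1. No measurement shown offers an explanation for these small steps.

The compounds shown leave open whether an amine or a carboxylic acid on this aromatic carbon, or a longer chain in place of methyl on the ring amine nitrogen, would give a step beyond the scatter. As far as these compounds go, it also remains open whether the values stay this close when trifluoromethyl is replaced by chloro or methoxy.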